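The source may report more compounds than this note shows. Statements on the series, on what has been measured and on what is new or still open speak of the compounds shown alone.

Compound 1 `COc1ccc(-c2cc(=O)c3c(OC)cc(OC)cc3n2S(=O)(=O)c2ccc(C)cc2)cc1`: in an ADME assay on BJ cells (Homo sapiens) for antiproliferative activity, with a stated time of 72 h (a lower number here means that less compound is needed, a higher number that more compound is needed for the effect), compound 1 gives > 44800 nM, a limit of the assay.
Compound 2 `COc1ccc(-c2cc(=O)c3c(OC)cc(OC)cc3n2S(=O)(=O)Cc2ccccc2)cc1`: in this assay compound 2 gives > 34400 nM, a limit of the assay.

Within the data shown here, compound 2 stands at a limit only; no number is known for it, and the one other value is also a limit, so the series so far shows nothing but the limit of > 34400 nM in this assay, at which 1 of the 2 values shown sits, and (the limit of > 44800 nM in this assay, at which 1 of the 2 values shown sits). Among the measured compounds shown here, the single step that exists, a step that the two limits leave unreadable from compound 1 to compound 2, cannot be read for size or direction.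

Compound 3 `COc1ccc(-c2cc(=O)c3c(OC)cc(OC)cc3n2S(=O)(=O)c2ccc(Br)s2)cc1` differs from compound 2 by 5-bromothiophen-2-yl in place of benzyl on a sulfonyl sulfur. For the measured compounds named here, no measured step bears readably on this change; the only comparison available, from compound 1 to compound 2, is unreadable. What can be expected is therefore weak: for the step that the limit leaves unreadable from compound 2 to compound 3 no size beyond the scatter is expected in either direction, and the most likely outcome for compound 3 is again a limit. Compound 3 is estimated at 40000 nM, with a range from 12000 nM to 120000 nM.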

Compound 3, half-maximal effective concentration: > 48200 nM
Compound 3: no number, only a limit; the forecaster's own chance of this, stated with the estimate: 80%; middle value at least 1.2-fold (0.08 log units) from the limit.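

Compound 3 gives > 48200 nM in this assay, again a limit of the assay. The steps linking compound 1, compound 2 and compound 3 cannot be read for size or direction. The compounds shown leave open whether any group on the sulfonyl sulfur yields a measurable number in this assay.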